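The compounds below may be only part of what the source reports. "The series", "measured", "known", "first", "only" and "open" are said of these compounds alone.

Measured in a functional assay on MDA-N cells (Homo sapiens); a higher number here means a weaker inhibitor of growth, a lower number a stronger inhibitor of growth:

- compound 1 `Cc1cc(C)c2c(O)cc(-c3ccc(Cl)cc3)nc2n1`: 3630 nM
- compound 2 `COc1cccc(-c2cc(=O)c3ccc(C)nc3[nH]2)c1`: 11 nM
- compound 3 `COc1ccc(-c2cc(O)c3c(C)cc(C)nc3n2)cc1`: 33100 nM

Compound 1 holds the second highest of these three numbers. Compound 4 `Cc1ccnc2nc(-c3ccc(Cl)cc3)cc(O)c12` keeps the core of compound 1 and changes in one place: hydrogen in place of methyl on an aromatic carbon. Within the data shown here, no measured step covers this place. The nearest guide is the modest 9.1-fold higher number from compound 1 to compound 3 (0.96 log units; beyond the scatter), made elsewhere on the molecule. Compound 2 differs from compound 1 in more than one place and offers no clean reading. No step beyond the scatter is therefore expected in this assay, with only a slight lean towards a higher number. The expected step is a 1.4-fold higher number from compound 1 to compound 4 (0.14 log units; within the scatter). For compound 4 the estimated value is 5000 nM, with an expected range of 1000 nM to 25000 nM.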

Compound 4, concentration for 50% growth inhibition: 1320 nM
Estimate against measurement, compound 4: 3.8-fold (0.58 log units) above; the measured number falls inside the stated range.
By their numbers in this assay, from the lowest: compound 2; then compound 4; then compound 1; then compound 3.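

In this assay the methyl next to the ring nitrogen is not needed for growth inhibition: hydrogen in its place gives a 2.8-fold lower number from compound 1 to compound 4 (0.44 log units; beyond the scatter) and so a modest gain in strength. Among these compounds, this is the first reading at this position, as the earlier step exchanged chloro for methoxy elsewhere on the molecule. No evidence bearing on the origin of this step is available.

From the compounds shown here alone, it remains open whether an amine or a longer chain such as ethyl at this place would keep the gain. Also open, going by these compounds, is whether the remaining methyl group can be exchanged for hydrogen with a similar result.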